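The source may hold more compounds than are shown below. What is called first, only, known or untested is meant among the compounds shown, and "the series" means these compounds.

Measured so far in a functional assay on 786-0 cells (Homo sapiens) for antiproliferative activity, read by sulforhodamine B assay, with a stated time of 48 h; a higher number here means a weaker inhibitor of growth, a lower number a stronger inhibitor of growth:

Compound 1, `COc1ccc2c(c1)C(=O)OC(CO)C2`, gives >= 250 ug/mL; this value is a limit of the assay, not a number.
Compound 2, `COc1ccc2c(c1)C(=O)OC(CCCO)C2`, gives 102 ug/mL.

Going by the values given here, compound 2 thus holds the only actual number in this assay; the other entry, for compound 1, is a limit. Among the compounds with values here, the one measured step, an at least 2.4-fold lower number from compound 1 to compound 2 (0.38 log units; beyond the scatter), is the only comparison available, and its size is bounded from below only, because the limit of >= 250 ug/mL in this assay, at which 1 of the 2 values shown sits, keeps the true distance open.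

Compound 3, `CCCCCOCCCC1Cc2ccc(OC)cc2C(=O)O1`, is not yet measured. It differs from compound 2 by pentyl in place of hydrogen on an oxygen on a saturated carbon. Within the data shown here, no measured step repeats this exact change: the step from compound 1 to compound 2 lengthened the chain while keeping the hydroxy, whereas here the hydroxy hydrogen itself is exchanged for pentyl. That step shows a longer chain lowering the number; the present change also lengthens the chain, though through the oxygen. On that thin basis compound 3 is expected to show a modest step, a 2.0-fold lower number from compound 2 to compound 3 (0.31 log units; beyond the scatter), toward a lower number. The estimate for compound 3 in this assay is therefore 50 ug/mL, within a range from 15 ug/mL to 160 ug/mL.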

Compound 3, concentration for 50% growth inhibition: 31.9 ug/mL
Estimate against measurement, compound 3: 1.6-fold (0.20 log units) above, within the range that was stated.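

In this assay, going by these compounds alone, pentyl in place of hydrogen on the oxygen gives a 3.2-fold lower number from compound 2 to compound 3 (0.50 log units; beyond the scatter), the first step with a real number at both ends. The hydroxy hydrogen at the end of the chain is therefore not required for growth inhibition in this pair, since compound 3 lacks it and still has the lower number; the earlier step, an at least 2.4-fold lower number from compound 1 to compound 2 (0.38 log units; beyond the scatter), kept the hydroxy throughout and could be bounded from one side only. Nothing shown here gives a cause for the new step, so it remains an observation about this one position and this one change.

Going by these compounds, what methyl or octyl on the same oxygen would give remains open, and with it whether the number follows the length of the group or only the loss of the hydrogen. Also open, on these data alone, is how an amine or a carboxylic acid at the end of the chain would compare with the hydroxy and the pentyloxy on the shared core.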